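A few compounds are considered here, and "the series" means these few. Any claim that something is new, unique, unknown or untested is made for them only; others in the source may bear on it.

Compound 2 `CC(C)c1onc(-c2c(Cl)cccc2Cl)c1COc1ccc(-c2nc3ccc(C(=O)O)cc3n2CC2CCCCC2)c(F)c1` was tested in an assay on Huh-7 cells for agonist activity at Bile acid receptor (Homo sapiens), read by a luciferase reporter (a higher number here means that more compound is needed for the effect, a lower number that less compound is needed), where compound 2 gives 7.8 nM. Of the three compounds measured, that is the largest number, although compound 3 `CC(C)Cn1c(-c2ccc(OCc3c(-c4c(Cl)cccc4Cl)noc3C(C)C)cc2)nc2ccc(C(=O)O)cc21`, which in this assay gives 5.26 nM, sits within the usual scatter of it. The clear separation is from compound 1 `CCC(CC)n1c(-c2ccc(OCc3c(-c4c(Cl)cccc4Cl)noc3C(C)C)cc2F)nc2ccc(C(=O)O)cc21`, which in this assay gives 1.3 nM; the step of a 6.0-fold higher number from compound 1 to compound 2 (0.78 log units; beyond the scatter) comes from exchanging the group on the aromatic nitrogen.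

Compound 4 `CC(C)c1onc(-c2c(Cl)cccc2Cl)c1COc1ccc(-c2nc3ccc(C(=O)O)cc3n2CC2CCCCC2)c(Cl)c1` has not yet been measured. It differs from compound 2 in a single place: chloro in place of fluoro on an aromatic carbon. Among the compounds with values here, no measured step touches this halogen. Within the data shown here, the one step recorded, a 6.0-fold higher number from compound 1 to compound 2 (0.78 log units; beyond the scatter), alters a different part of the molecule, and compounds 1 and 3 differ from each other in two places at once, so their numbers cannot be separated into single changes. With nothing directly bearing on a fluoro-to-chloro swap, the reasonable expectation is a step of a 1.0-fold higher number from compound 2 to compound 4 (0.01 log units; within the scatter) that stays within the scatter of repeated measurements. Compound 4 is therefore expected to give about 8 nM in this assay, with a plausible range from 3 nM to 22 nM.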

Compound 4, half-maximal effective concentration: 7.6 nM
For compound 4 the middle estimate is 1.1-fold (0.02 log units) above the measured one, within the range that was stated.
By their numbers in this assay, from the lowest: compound 1; then compounds 3, 4 and 2 (each within the scatter of the next).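

Within the data shown here, the step of a 1.0-fold lower number from compound 2 to compound 4 (0.01 log units; within the scatter) in this assay is the first direct reading of a single change at this halogen position, on a six-membered aromatic ring of carbon only, ortho to a large group and meta to a large group. Among these compounds, it shows that, with cyclohexylmethyl on the aromatic nitrogen, chloro in place of fluoro gives no change that can be told apart from the scatter of repeated measurements, something the earlier compounds could not show, as compound 1 and compound 2 share fluoro and compound 3 differs from both in more than one place. No measurement is available that explains this result.

As far as these compounds go, it remains open whether a group other than a halogen at this position, such as methyl, methoxy or a nitrile, or simply hydrogen with the cyclohexylmethyl group kept in place, would also leave the number within the scatter. Also open, from the compounds shown here alone, is whether chloro in place of fluoro would behave the same way with the pentan-3-yl group of compound 1 on the aromatic nitrogen.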